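This account rests on a few compounds, and the source may have more. Where it says the series, first, only, none or still open, it means among the compounds named here.

Compound 3 `Cc1ccc(CSc2nnc(-c3ccc4c(c3)OCCO4)o2)cc1` is the starting point. In a functional assay on HepG2 cells (Homo sapiens) for antiproliferative activity, read by MTT assay, with a stated time of 48 h (a higher number here means a weaker inhibitor, a lower number a stronger inhibitor), compound 3 gives 41900 nM, which is the top of the three numbers shown, although every other compound lies within the usual scatter of it. Compound 1 `O=[N+]([O-])c1cccc(CSc2nnc(-c3ccc4c(c3)OCCO4)o2)c1` gives 38300 nM in this assay, and compound 2 `Clc1ccccc1CSc1nnc(-c2ccc3c(c2)OCCO3)o1` gives 22600 nM. Going by the values given here, the only change among the measured compounds that can be traced to one place is a 1.9-fold higher number from compound 2 to compound 3 (0.27 log units; within the scatter), a move that stays within the scatter.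

Compound 4 `Brc1ccc(CSc2nnc(-c3ccc4c(c3)OCCO4)o2)cc1` is not yet measured. It differs from compound 3 by bromo in place of methyl on an aromatic carbon. Among the compounds with values here, no measured step exchanges a halogen for a methyl at this position, so the expectation rests on what the three compounds show: a nitro, a chloro and a methyl substituent on the pendant ring all give numbers within the scatter of one another, and a 1.9-fold higher number from compound 2 to compound 3 (0.27 log units; within the scatter) is the only step that speaks to a change on that ring. The bromo is therefore not expected to move the number beyond the scatter in either direction. Compound 4 is estimated to give 36000 nM in this assay, within 16000 nM to 80000 nM, corresponding to an expected step of a 1.2-fold lower number from compound 3 to compound 4 (0.07 log units; within the scatter).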

Compound 4, half-maximal inhibitory concentration: 8540 nM
Compound 4: middle estimate off by 4.2-fold (0.62 log units), on the high side, outside the stated range (below it).
By their numbers in this assay, from the lowest: compound 4; then compounds 2, 1 and 3 (each within the scatter of the next).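

In this assay, bromo in place of methyl on an aromatic carbon, para to a large group, gives (a 4.9-fold lower number from compound 3 to compound 4 (0.69 log units; beyond the scatter)), and this is the first step among these compounds to lie beyond the scatter, so this place on the pendant ring does respond to what it carries, which compounds 1, 2 and 3, all within the scatter of one another, gave no sign of. The 4-bromophenyl group also stands apart from the 2-chlorophenyl group (a 2.6-fold lower number from compound 2 to compound 4 (0.42 log units; beyond the scatter)), although that step changes both the halogen and its place on the ring, so it cannot assign the difference to either one alone. Nothing available explains why bromo differs from methyl here.

The compounds shown leave open whether a fluoro, a chloro, an iodo, a methoxy or an amine in that same place would give a number close to that of compound 4 or close to that of compound 3. They also leave open whether bromo elsewhere on the pendant ring would produce a comparable step, or whether this step is tied to that one place.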